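The compounds below may be only part of what the source reports. "The series", "measured", "known", "first", "only" and "open" are said of these compounds alone.

Compound 1 `COc1ccccc1C[C@H]1COC(=O)[C@@H]1Cc1ccc(Cl)c(Cl)c1` gives 24000 nM
Compound 2 `Cc1cccc(C[C@H]2COC(=O)[C@@H]2Cc2ccc(Cl)c(Cl)c2)c1` gives "not determined" (no result reported)
Compound 3 `CCCCc1ccc(C[C@H]2COC(=O)[C@@H]2Cc2ccc(Cl)c(Cl)c2)cc1` gives 27000 nM

These three results come from a functional assay on HeLa cells (Homo sapiens) for cytotoxicity, read by WST assay, with a stated time of 48 h (a lower number here means that less compound is needed, a higher number that more compound is needed for the effect), and belong to compounds with a shared core. Compound 1 at 24000 nM and compound 3 at 27000 nM lie within the usual scatter of each other, so neither ranks ahead, and compound 2 has no number to compare.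

Going from compound 3 to compound 4 `O=C1OC[C@H](Cc2ccc(F)cc2)[C@H]1Cc1ccc(Cl)c(Cl)c1` the change is fluoro in place of butyl on an aromatic carbon, para to a large group. Going by the values given here, no two measured compounds differ in only one place, so no direct step serves as a guide. Even so, compound 1 at 24000 nM and compound 3 at 27000 nM carry different groups and still sit within the scatter, which points to a small change here. The estimated 1.1-fold higher number from compound 3 to compound 4 (0.05 log units; within the scatter) is expected to stay within the usual scatter, with no direction favoured. In this assay the estimate for compound 4 is 30000 nM, with an expected range from 12000 nM to 70000 nM.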

Compound 4, half-maximal effective concentration: 19000 nM
Compound 4: the middle estimate sits 1.6-fold (0.20 log units) above what was measured, and the stated range covers the measured number.
By their numbers in this assay, from the lowest: compounds 4, 1 and 3 (each within the scatter of the next).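

In this assay, going by these compounds alone, fluoro in place of butyl on an aromatic carbon, para to a large group, gives a 1.4-fold lower number from compound 3 to compound 4 (0.15 log units; within the scatter) and is the first direct step between two compounds that differ in one place. Even with a single fluorine atom replacing a butyl chain of four carbons, the two numbers cannot be told apart. Exchanging the whole 2-methoxyphenyl for 4-fluorophenyl gives a 1.3-fold lower number from compound 1 to compound 4 (0.10 log units; within the scatter) and likewise separates nothing, and no measurement here explains why these exchanges leave the numbers so close.

The compounds shown therefore leave open whether any group in this place can move the number beyond the scatter. As far as these compounds go, what an amine, a carboxylic acid or a chain longer than butyl would do there remains unknown.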